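Removing the isopropyl from the amine of compound 1

The source may hold more compounds than are shown below. What is called first, only, known or untested is meant among the compounds shown, and "the series" means these compounds.

Going by the values given here, compound 1 `COc1cccc(-c2c(C)n(Cc3c(F)cccc3F)c(=O)n(C[C@H](NC(C)C)C3CCCCC3)c2=O)c1F` gives 23 nM in an assay on HEK293 cells for binding affinity to Gonadotropin-releasing hormone receptor (Homo sapiens), read by radioligand binding (a higher number here means a weaker inhibitor, a lower number a stronger inhibitor), the highest of the three numbers measured so far. Compound 2 `COc1cccc(-c2c(C)n(Cc3c(F)cccc3F)c(=O)n(C[C@@H](C3CCCCC3)N(C)C)c2=O)c1F` gives 4.1 nM, and compound 3 `COc1cccc(-c2c(C)n(Cc3c(F)cccc3F)c(=O)n(C[C@H](N)C3CCCC3)c2=O)c1F` gives 10 nM. Two steps lead away from compound 1: a 5.6-fold lower number from compound 1 to compound 2 (0.75 log units; beyond the scatter) and a 2.3-fold lower number from compound 1 to compound 3 (0.36 log units; beyond the scatter); between the other two, a 2.4-fold higher number from compound 2 to compound 3 (0.39 log units; beyond the scatter). Compound 4 `COc1cccc(-c2c(C)n(Cc3c(F)cccc3F)c(=O)n(C[C@H](N)C3CCCCC3)c2=O)c1F` differs from compound 1 in one place: hydrogen in place of isopropyl on an amine nitrogen. The step to compound 3 bears most directly on this, although it carries a second change as well, and the step to compound 2 shows that the amine substituent matters. Because a 2.3-fold lower number from compound 1 to compound 3 (0.36 log units; beyond the scatter) already includes the exchange of isopropyl for hydrogen, a modest fall is expected, that is a 2.6-fold lower number from compound 1 to compound 4 (0.41 log units; beyond the scatter). Compound 4 is estimated at 9 nM, with a range from 3 nM to 25 nM.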

Compound 4, inhibition constant: 6.5 nM
The estimate for compound 4 lay 1.4-fold (0.14 log units) above the measured number; low and high end bracket the measured number.
By their numbers in this assay, from the lowest: compounds 2, 4 and 3 (each within the scatter of the next, the first and the last beyond it); then compound 1.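

Taken alone, hydrogen in place of isopropyl on the amine nitrogen gives a 3.5-fold lower number from compound 1 to compound 4 (0.55 log units; beyond the scatter) in this assay and shows, without the ring change carried by the earlier step to compound 3, that the isopropyl group is itself linked to weaker binding. Both a 1.5-fold lower number from compound 3 to compound 4 (0.19 log units; within the scatter) with cyclohexyl in place of cyclopentyl and a 1.6-fold higher number from compound 2 to compound 4 (0.20 log units; within the scatter) with amino in place of dimethylamino stay within the scatter, so neither change separates these compounds. Nothing available accounts for these steps.

Going by these compounds, whether methylamino or acetamido in place of amino, or phenyl in place of cyclohexyl, would keep binding at this level stays open.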